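This account rests on a few compounds, and the source may have more. Where it says the series, first, only, none or still open, it means among the compounds named here.

Measured so far:

Compound 1, `CS(=O)(=O)CCCn1c(Cn2c(=O)n(C3CC3)c3ccncc32)cc2cc(Cl)ccc21`. In an ADME assay on HeLa cells (Homo sapiens) for cytotoxicity, read by ATP content, with a stated time of 3 days (a lower number here means that less compound is tolerated, a higher number that more compound is tolerated), compound 1 gives > 50000 nM, which is a limit of the assay and not a number.

Compound 2, `CC(C)(C)n1c(=O)n(Cc2cc3cc(Cl)ccc3n2CCCS(C)(=O)=O)c2cnccc21`. In this assay compound 2 gives > 50000 nM, again a limit of the assay and not a number.

Compound 2 therefore stands at the limit of > 50000 nM in this assay, at which 2 of the 2 values shown sit, together with compound 1; no numerical position within the series can be given for it. Going by the values given here, the only measured step, a step that the two limits leave unreadable from compound 1 to compound 2, exchanges tert-butyl for cyclopropyl on an aromatic nitrogen. Both ends sit at the limit, and its size and direction are not readable.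

Compound 3, `CS(=O)(=O)CCCn1c(Cn2c(=O)n(CC3CC3)c3ccncc32)cc2cc(Cl)ccc21`, differs from compound 2 in one place: cyclopropylmethyl in place of tert-butyl on an aromatic nitrogen. The change touches the same aromatic nitrogen that the measured step addressed, with a group of the same heavy-atom count entering. Among the compounds with values here, no measured step gives a readable size for any change at this position, so nothing points to a shift beyond the scatter in this assay in either direction.

For compound 3 the expected outcome is again a limit in this assay, the step of a number no higher from compound 2 to compound 3 (the limit leaves the size open) being estimated as none beyond the scatter. The estimate for compound 3 is 50000 nM, with an expected range from 25000 nM to 100000 nM.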

Compound 3, half-maximal cytotoxic concentration: > 50000 nM
Compound 3: only a limit was reported; the forecaster's own chance of this, stated with the estimate: 80%; the middle value sits exactly at the limit.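

In this assay no new step can be read: compound 3 sits at a limit of the assay, as do compound 1 and compound 2, and the steps joining them have neither a readable size nor a direction. The compounds shown leave open whether cyclopropyl, tert-butyl and cyclopropylmethyl on the aromatic nitrogen differ at all in this read-out: the limit of > 50000 nM in this assay, at which 3 of the 3 values shown sit.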